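Lengthening the alkyl chain on the shared core

The compounds below may be only part of what the source reports. "The series", "measured", "known", "first", "only" and "open" are said of these compounds alone.

Measured compounds:
compound 1 `CCCCCCNc1nc(SCc2ccc(C(F)(F)F)cc2)nc2ccccc12` with 24300 nM
compound 2 `CCCCCCCCNc1nc(SCc2ccc(C(F)(F)F)cc2)nc2ccccc12` with 26100 nM

Of the compounds shown here, two sharing one core have been measured in a functional assay on MCF7 cells (Homo sapiens) for cytotoxicity, read by MTT assay, with a stated time of 72 h; on this read-out higher numbers stand for weaker inhibition and lower numbers for stronger inhibition. Compound 1 gives 24300 nM and compound 2 gives 26100 nM. Compound 2 carries the higher of the two numbers, but the step of a 1.1-fold higher number from compound 1 to compound 2 (0.03 log units; within the scatter) is within the scatter, so the two values cannot be told apart. That step came from ethyl in place of hydrogen on a saturated chain carbon, six bonds along the chain from a nitrogen on an aromatic ring being, in effect, an ethyl in place of hydrogen on a saturated chain carbon, six bonds along the chain from a nitrogen on an aromatic ring.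

Compound 3 `CCCCCCCCCCCCNc1nc(SCc2ccc(C(F)(F)F)cc2)nc2ccccc12` has not yet been measured. It differs from compound 2 by butyl in place of hydrogen on a saturated chain carbon, eight bonds along the chain from a nitrogen on an aromatic ring. For the measured compounds named here, the only step that bears on this change is the one from compound 1 to compound 2, which was within the scatter; it extends the same chain by a smaller amount. Nothing else is known about longer chains here. The expected step is therefore a 1.1-fold lower number from compound 2 to compound 3 (0.04 log units; within the scatter), that is, no change beyond the scatter in this assay. Compound 3 is estimated at 24000 nM, with a range from 8000 nM to 70000 nM.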

Compound 3, half-maximal inhibitory concentration: > 50000 nM
Compound 3: only a limit was reported; the forecaster's own chance of this, stated with the estimate: 15%; at least 2.0-fold (0.31 log units) between middle value and limit.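

In this assay, for the compounds shown here, compound 3 gives > 50000 nM, which is a limit of the assay and not a number: the limit of > 50000 nM in this assay, at which 1 of the 3 values shown sits. Even so, the limit is enough for one firm reading, an at least 2.0-fold higher number from compound 1 to compound 3 (0.31 log units; beyond the scatter), the first step at this place to pass the scatter, whereas an at least 1.9-fold higher number from compound 2 to compound 3 (0.28 log units; that floor lies within the scatter) has a floor that stays inside it. The added hexyl therefore shifts the read-out toward weaker inhibition, which the smaller ethyl in a 1.1-fold higher number from compound 1 to compound 2 (0.03 log units; within the scatter) did not do, while the added butyl alone cannot yet be said to do so.

As far as these compounds go, what remains open is how far the true value of compound 3 lies past the limit, and so how large either step really is. Also open, from the compounds shown here alone, is what a decyl chain would give on the same nitrogen, which could show whether the change along the chain is gradual or abrupt, and whether a chain of similar length ending in an amine or a carboxylic acid would behave like the plain alkyl chains.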